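Piperidin-1-yl in Place of Methoxyethylamino on the Shared Core

The source may report more compounds than this note shows. Statements on the series, on what has been measured and on what is new or still open speak of the compounds shown alone.

Compound 2 `COCCNc1nc(C)cc2nn(-c3ccccc3)c(N)c12` gives 2% in an assay on isolated protein for inhibition of RAC-beta serine/threonine-protein kinase (Homo sapiens), read by mobility shift assay, tested at 30 uM (on this read-out lower numbers stand for less inhibition and higher numbers for more inhibition at the one concentration tested (going by the name of the read-out)), the highest of the two numbers shown; compound 1 `Cc1cc2c(c(N)nn2C)c(N2CCCCC2)n1` gives 0% in this assay, a difference within the scatter. Compound 3 `Cc1cc2nn(-c3ccccc3)c(N)c2c(N2CCCCC2)n1` awaits measurement. Change from compound 2: piperidin-1-yl in place of (2-methoxyethyl)amino on an aromatic carbon. No step beyond the scatter is expected in this assay, because compound 1 already carrying piperidin-1-yl gives 0%. The expected step is a number 1 percentage points lower from compound 2 to compound 3 (within the scatter), none beyond the scatter. Compound 3 is expected to give 1% in this assay, in a range from -6% to 10%.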

Compound 3, a percentage reported as inhibition, at one concentration (the size of the read-out at that concentration, not a potency): -7%
For compound 3 the middle estimate is 8 percentage points above the measured one; measured number outside the range, below it.
By their numbers in this assay, from the lowest: compounds 3, 1 and 2 (each within the scatter of the next).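

In this assay, piperidin-1-yl in place of (2-methoxyethyl)amino gives a number 9 percentage points lower from compound 2 to compound 3 (within the scatter), so on this phenyl-bearing core the ring and the open chain are not told apart at this position next to the ring nitrogen. Losing the hydrogen-bond donor of the amino group therefore brings no step beyond the scatter. No measured evidence bears on this result.

As far as these compounds go, whether a benzylamine or a longer chain ending in a carboxylic acid at this position would give a number clear of the scatter remains open. So does whether this position affects the read-out at all.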